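The source may report more compounds than this note shows. Statements on the series, on what has been measured and on what is new or still open speak of the compounds shown alone.

Values in a functional assay on cells (Melanoma cell, Homo sapiens) for inhibition; on this read-out higher numbers stand for weaker inhibition of growth and lower numbers for stronger inhibition of growth:
- compound 1 `Cc1cc(-c2nc3sc(C)cn3c2/C=N/NC(=N)N)c(C)s1`: 15100 nM
- compound 2 `N=C(N)N/N=C/c1c(-c2ccsc2)nc2sccn12`: 31600 nM
- compound 3 `N=C(N)N/N=C/c1c(-c2cccs2)nc2sccn12`: 28800 nM
- compound 4 `Cc1cc(-c2nc3sccn3c2/C=N/NC(=N)N)c(C)s1`: not yet measured

Compound 3, at 28800 nM, lies within the scatter of both compound 2 and compound 1, so its place among the three is not firmly settled. The next change is 2,5-dimethylthiophen-3-yl in place of thiophen-2-yl on an aromatic carbon. In words, 2,5-dimethylthiophen-3-yl replaces thiophen-2-yl on an aromatic carbon of a five-membered aromatic ring with 2 nitrogen, part of a fused or bridged system of two rings.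

For the measured compounds named here, the only measured step that bears on this directly is a 1.1-fold lower number from compound 2 to compound 3 (0.04 log units; within the scatter). Going by the values given here, it moves the thiophene attachment but adds no methyl groups, so no measured step isolates the full change. Compound 1 already carries 2,5-dimethylthiophen-3-yl, on a core with one further methyl, and compound 1 gives 15100 nM. This is only indirect support, but it points to a small step toward a lower number in this assay, with none expected beyond the scatter.

The expected change is a 1.4-fold lower number from compound 3 to compound 4 (0.16 log units; within the scatter). The estimated value for compound 4 is 20000 nM, with an expected range of 11000 nM to 36000 nM.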

Compound 4, concentration for total growth inhibition: 30900 nM
Compound 4: the middle estimate sits 1.5-fold (0.19 log units) below what was measured; measured number inside the range.
By their numbers in this assay, from the lowest: compounds 1, 3, 4 and 2 (each within the scatter of the next, the first and the last beyond it).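

In this assay, placing 2,5-dimethylthiophen-3-yl on this aromatic carbon of the shared core gives a 1.1-fold higher number from compound 3 to compound 4 (0.03 log units; within the scatter) against thiophen-2-yl and a 1.0-fold lower number from compound 2 to compound 4 (0.01 log units; within the scatter) against thiophen-3-yl, so on this core the three thiophene groups cannot be told apart in this read-out. For the compounds shown here, the only step here beyond the scatter comes from a different place, with hydrogen in place of methyl on an aromatic carbon of the core giving a 2.0-fold higher number from compound 1 to compound 4 (0.31 log units; beyond the scatter), a modest change that shows the lower number of compound 1 goes with this core methyl and not with the 2,5-dimethylthiophen-3-yl group, at least in this one pair. Nothing available on these compounds offers a reason for either result.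

As far as these compounds go, the core methyl step is read on a single thiophene group, so whether it holds with thiophen-2-yl or thiophen-3-yl remains open, as does the effect of an ethyl group or a chlorine atom at that core carbon. From the compounds shown here alone, it is also open whether a phenyl or pyridyl ring on the first aromatic carbon would stay as flat as the thiophenes do.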